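Swapping Chloro for Ethynyl on a Shared Inhibitor Core

The source may hold more compounds than are shown below. What is called first, only, known or untested is meant among the compounds shown, and "the series" means these compounds.

Three measured compounds share one core and differ only in the group on the six-membered ring. Compound 1 `COc1ccn2ncc(/C=N/N(C)S(=O)(=O)c3cc([N+](=O)[O-])ccc3C)c2c1` carries a methoxy there; in an assay on isolated protein for inhibition of phosphatidylinositol 4,5-bisphosphate 3-kinase catalytic subunit beta isoform (Homo sapiens), read by 33P incorporation, with a stated time of 60 min (a lower number here means a stronger inhibitor, a higher number a weaker inhibitor), compound 1 gives only a limit, > 1000 nM. Compound 2 `CC(=O)Oc1ccn2ncc(/C=N/N(C)S(=O)(=O)c3cc([N+](=O)[O-])ccc3C)c2c1` carries an acetoxy; in this assay compound 2 gives only a limit, > 1000 nM. For the measured compounds named here, compound 3 `Cc1ccc([N+](=O)[O-])cc1S(=O)(=O)N(C)/N=C/c1cnn2ccc(Cl)cc12` carries a chloro and is the one compound with an actual number: in this assay compound 3 gives 390 nM. The steps of an at least 2.5-fold lower number from compound 1 to compound 3 (0.40 log units; beyond the scatter) and an at least 2.5-fold lower number from compound 2 to compound 3 (0.40 log units; beyond the scatter) both run towards compound 3, while the step that the two limits leave unreadable from compound 1 to compound 2 cannot be read because both values sit at the limit of > 1000 nM in this assay, at which 2 of the 3 values shown sit.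

Compound 4 `C#Cc1ccn2ncc(/C=N/N(C)S(=O)(=O)c3cc([N+](=O)[O-])ccc3C)c2c1` differs from compound 3 by ethynyl in place of chloro on an aromatic carbon. Going by the values given here, no measured step exchanges chloro for ethynyl, so the two known steps give only the sense that this position tolerates a small, uncharged group. The expected step is a 1.2-fold higher number from compound 3 to compound 4 (0.06 log units; within the scatter), a change within the usual scatter. Compound 4 is therefore estimated at 450 nM, with a plausible range from 150 nM to 1300 nM.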

Compound 4, half-maximal inhibitory concentration: 30 nM
Beside the measured number, compound 4's estimate is 15-fold (1.18 log units) above it; measured number below the stated range.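

For the compounds shown here, at this position on the six-membered ring, the earlier compounds showed only that chloro differs from methoxy and acetoxy, not how strongly a small swap can register. In this assay, ethynyl, with 2 heavy atoms, in place of chloro, with 1 heavy atom, gives a 13-fold lower number from compound 3 to compound 4 (1.11 log units; beyond the scatter), so neither group has any hydrogen-bond donors or acceptors, yet the change is large. Against the other two groups the record shows an at least 33-fold lower number from compound 2 to compound 4 (1.52 log units; beyond the scatter) and an at least 33-fold lower number from compound 1 to compound 4 (1.52 log units; beyond the scatter), and these sizes are minimums, because each starts from a limit of the assay rather than a number: the limit of > 1000 nM in this assay, at which 2 of the 4 values shown sit.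

The compounds shown leave open whether the triple bond itself matters, or whether a nitrile, a vinyl group or a longer alkyne such as propynyl would serve as well. They also leave open why ethynyl gives a lower number than chloro here.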